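The compounds below may be only part of what the source reports. "The series", "measured", "known", "first", "only" and "open" are said of these compounds alone.

The study concerns an assay on isolated protein for inhibition of Amine oxidase [flavin-containing] B (Homo sapiens), read by fluorescence, with a stated time of 15 min; a higher number here means a weaker inhibitor, a lower number a stronger inhibitor. Compound 1, with the structure `COc1ccc(/C=C/c2cc(OC)cc(OC)c2/C=C/C(=O)c2cc3cc(Cl)ccc3oc2=O)cc1`, gives in this assay only a limit, > 60000 nM. Compound 2, with the structure `COc1ccc(/C=C/c2cc(OC)cc(OC)c2/C=C/C(=O)c2cc3cc(Br)cc(OC)c3oc2=O)cc1`, likewise returns only a limit in this assay, > 60000 nM. Among the compounds with values here, compound 3, with the structure `CCOc1ccc2cc(C(=O)/C=C/c3c(/C=C/c4ccc(OC)cc4)cc(OC)cc3OC)c(=O)oc2c1`, is the one member of the group with an actual number in this assay, at 48100 nM. Within the data shown here, compound 1 thus stands at the limit of > 60000 nM in this assay, at which 2 of the 3 values shown sit, so only a ceiling is known for it, and no step between two measured compounds can be drawn from these three. Compound 4, with the structure `COc1ccc(/C=C/c2cc(OC)cc(OC)c2/C=C/C(=O)c2cc3cc(C)ccc3oc2=O)cc1`, has not yet been measured. It differs from compound 1 by methyl in place of chloro on an aromatic carbon. The expected step is a number no higher from compound 1 to compound 4 (the limit leaves the size open), which is no more than the usual scatter and in no particular direction. Compound 4 is therefore expected to come in at roughly 60000 nM, within a range from 20000 nM to 180000 nM, and may well again be reported only as a limit.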

Compound 4, half-maximal inhibitory concentration: 5090 nM
The estimate for compound 4 lay 12-fold (1.07 log units) above the measured number, outside the stated range (below it).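

In this assay, within the data shown here, methyl in place of chloro on this aromatic carbon gives an at least 11-fold lower number from compound 1 to compound 4 (1.07 log units; beyond the scatter), the first step that can be read in this set. It shows that this place on the shared core is sensitive: exchanging one heavy atom for another, with no change in ring, charge or hydrogen-bond donors and acceptors, is enough to turn a compound with no measured number into one with a measured value. The full size of the step remains unknown, as its starting point is only a limit: the limit of > 60000 nM in this assay, at which 2 of the 4 values shown sit.

This single pair cannot show why methyl outperforms chloro, nor whether the gain belongs to methyl alone. As far as these compounds go, whether a longer chain such as ethyl, an amine or plain hydrogen at this carbon would do better or worse remains open.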